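The compounds below may be only part of what the source reports. "The series", "measured", "known", "first", "only" and "open" are said of these compounds alone.

Compound 1 `CN(C)C(=O)c1ncc([N+](=O)[O-])[nH]1` gives in a toxicity assay on HepG2 cells (Homo sapiens) for inhibition, read by resazurin assay, with a stated time of 24 h (on this read-out lower numbers stand for higher toxicity in this test and higher numbers for lower toxicity in this test), only the limit > 100000 nM.
Compound 2 `CNC(=O)c1ncc([N+](=O)[O-])[nH]1` gives in this assay only the limit > 100000 nM.
Compound 3 `NC(=O)c1nc([N+](=O)[O-])cn1Cc1ccc(OC(F)(F)F)cc1` gives in this assay only the limit > 100000 nM.

All three measured compounds thus sit at the same limit of this assay, and none of them yields a number. Compound 1 and compound 2 differ in one place: methyl in place of hydrogen on an amide-type nitrogen. The step this made, a step that the two limits leave unreadable from compound 2 to compound 1, cannot be read, because both ends are limits; what is known is the limit of > 100000 nM in this assay, at which 3 of the 3 values shown sit.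

Compound 4 `CNC(=O)c1nc([N+](=O)[O-])cn1Cc1ccc(OC(F)(F)F)cc1` has not been measured in this assay. It arises from compound 3 by methyl in place of hydrogen on an amide-type nitrogen. Among the compounds with values here, this is the same kind of change as the one from compound 2 to compound 1, but not the same: in compound 2 the other neighbours of the amide-type nitrogen are carbonyl carbon and saturated chain carbon, whereas in compound 3 the only other neighbour is carbonyl carbon. The difference between the two cores, compound 2 against compound 3, is not broken down here.

The expected step is a number no higher from compound 3 to compound 4 (the limit leaves the size open), close to no change. This rests on compound 3 sitting at the limit > 100000 nM. It also rests on the same kind of change between compound 2 and compound 1 leaving both at the limit, as the limit of > 100000 nM in this assay, at which 3 of the 3 values shown sit, shows. Compound 4 is therefore expected to give about 100000 nM in this assay, most likely again only as a limit, with a range from 50000 nM to 300000 nM.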

Compound 4, half-maximal cytotoxic concentration: > 100000 nM
Compound 4: no number, only a limit (the forecaster's own chance of this, stated with the estimate: 85%); the middle value sits exactly at the limit.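

Compound 3 and compound 4 each give only a limit and not a number, so the change of hydrogen to methyl on the amide-type nitrogen yields no step that can be read, and the result stays where the whole series sits: the limit of > 100000 nM in this assay, at which 4 of the 4 values shown sit.

The compounds shown leave open what actual number any of the four would take in this assay, and so whether this methyl or the difference between the cores matters there at all.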